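Working notes: fluoro to bromo in a cytotoxicity series

The source may report more compounds than this note shows. Statements on the series, on what has been measured and on what is new or still open speak of the compounds shown alone.

Measured compounds:
compound 1, `CC(C)COc1cccc(-c2ccc(C(=O)N(Cc3cccc(OCCCCCC(=O)O)c3)C(C)C)cc2)c1`, gives > 26000 nM in an ADME assay on Raji cells (Homo sapiens) for cytotoxicity, read by CellTiter-Glo and resazurin assay, with a stated time of 72 h; on this read-out lower numbers stand for an effect already at smaller amounts and higher numbers for an effect only at larger amounts of compound
compound 2, `CC(C)N(Cc1cccc(OCCCCCC(=O)O)c1)C(=O)c1ccc(-c2cccc(F)c2)cc1`, gives > 26000 nM in this assay

Both values are limits of the assay and not numbers. Compound 1 sits at a limit. Compound 2 likewise sits at a limit, so its standing on this read-out is known only as being at or beyond that point. Both values sit at the limit of > 26000 nM in this assay, at which 2 of the 2 values shown sit, and the step that the two limits leave unreadable from compound 1 to compound 2 cannot be read in size or direction.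

Compound 3, `CC(C)N(Cc1cccc(OCCCCCC(=O)O)c1)C(=O)c1ccc(-c2cccc(Br)c2)cc1`, is not yet measured. It differs from compound 2 by bromo in place of fluoro on an aromatic carbon. Within the data shown here, no measured step bears on an exchange of this kind; the only step in hand is unreadable, so there is no measured basis for expecting a change beyond the scatter in either direction.

Compound 3 is therefore expected to remain at the limit as well, with an estimate of 40000 nM and a range from 15000 nM to 120000 nM. The expected step that the limit leaves unreadable from compound 2 to compound 3 is estimated as no change beyond the scatter, with the caveat that the starting point is itself only a limit.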

Compound 3, half-maximal effective concentration: > 26000 nM
Compound 3: only a limit was reported (the forecaster's own chance of this, stated with the estimate: 85%); the middle value does not contradict the limit.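

No step among compound 1, compound 2 and compound 3 can be read in size or direction, because all three values are limits of the assay and not numbers: the limit of > 26000 nM in this assay, at which 3 of the 3 values shown sit.

The compounds shown leave open whether isobutoxy, fluoro and bromo on this aromatic carbon differ at all in this assay.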